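The compounds below may be only part of what the source reports. "The series", "measured", "known", "first", "only" and "open" are said of these compounds alone.

In a functional assay on HCT-116 cells (Homo sapiens) for antiproliferative activity, read by MTT assay, with a stated time of 24 h (a lower number here means a stronger inhibitor, a higher number a weaker inhibitor), three compounds have been read so far: compound 1 `COc1ccc(/C=C/C(=O)c2ccc(OC)c3c2OC(C)(C)C=C3)c(F)c1`, compound 2 `COc1ccc(C(=O)/C=C/c2cccc(F)c2)c2c1C=CC(C)(C)O2` and compound 3 `COc1ccc(/C=C/C(=O)c2ccc(OC)c3c2OC(C)(C)C=C3)cn1`. Compound 1 gives > 10000 nM, which is a limit of the assay and not a number. Compound 2 gives > 10000 nM, also a limit. Compound 3 gives > 10000 nM, again a limit. All three stand at the limit of > 10000 nM in this assay, at which 3 of the 3 values shown sit, so compound 2 has only a limit and no exact place among them.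

Compound 4 `COc1ccc(C(=O)/C=C/c2cccc(C(F)(F)F)c2)c2c1C=CC(C)(C)O2` differs from compound 2 in one place: trifluoromethyl in place of fluoro on an aromatic carbon, with trifluoromethyl in place of fluoro on an aromatic carbon. The measured steps that bear on this change are a step that the two limits leave unreadable from compound 1 to compound 2 and a step that the two limits leave unreadable from compound 2 to compound 3. Both alter the group that carries this substituent in compound 2, but neither has a readable size, so they support no particular size or direction in this assay. The expected step is a step that the limit leaves unreadable from compound 2 to compound 4, and it remains a weakly founded estimate. Compound 4 is estimated at 20000 nM, with an expected range of 8000 nM to 50000 nM.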

Compound 4, half-maximal inhibitory concentration: 9710 nM
Beside the measured number, compound 4's estimate is 2.1-fold (0.31 log units) above it, within the range that was stated.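

In this assay compound 4 is the only one of the compounds shown to give a number and not a limit, 9710 nM, so this aromatic carbon, meta to a large group, now has one exact reading. Compound 2 gives > 10000 nM, which is a limit of the assay and not a number. Trifluoromethyl in place of fluoro therefore gives an at least 1.0-fold lower number from compound 2 to compound 4 (0.01 log units; that floor lies within the scatter), so the change can be read only as a floor, and its full size and whether it exceeds the scatter remain unknown.

From the compounds shown here alone, the steps among compound 1, compound 2 and compound 3 cannot be read, and the true distance between compound 2 and compound 4 stays open. Also open, going by these compounds, is how an amine or a carboxylic acid on this same aromatic carbon would read in this assay.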